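Arylpiperazine ureas: alpha-1D binding, notes on compound 4

A few compounds are considered here, and "the series" means these few. Any claim that something is new, unique, unknown or untested is made for them only; others in the source may bear on it.

Measured compounds in an assay on liver for binding affinity to Alpha-1D adrenergic receptor (Homo sapiens), using microsomes; a lower number here means a stronger inhibitor, a higher number a weaker inhibitor:
compound 1 `COC(=O)C1=C(C)NC(=O)N(C(=O)NCCCN2CCN(c3ccccc3OC)CC2)C1c1ccc(F)c(F)c1`: 31 nM
compound 2 `COC(=O)C1=C(C)NC(=O)N(C(=O)NCCCN2CCN(c3cccc(Cl)c3)CC2)C1c1ccc(F)c(F)c1`: 37 nM
compound 3 `COCC1=C(C(=O)OC)C(c2cc(F)c(F)cc2F)N(C(=O)NCCCN2CCN(c3ccccc3C(N)=O)CC2)C(=O)N1`: 190 nM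

Compound 2 stands second highest of the three numbers; compound 1 lies within the scatter of it, while compound 3 sits beyond the scatter with a higher number. Compound 4 `COC(=O)C1=C(C)NC(=O)N(C(=O)NCCCN2CCN(c3ccccc3Cl)CC2)C1c1ccc(F)c(F)c1` is not yet measured. It differs from compound 2 by 2-chlorophenyl in place of 3-chlorophenyl on an amine nitrogen in a ring. Going by the values given here, the only measured step on that ring nitrogen is a 1.2-fold higher number from compound 1 to compound 2 (0.08 log units; within the scatter), which stayed within the scatter despite exchanging the whole aryl group. Among the compounds with values here, no measured pair isolates the present change, so no step beyond the scatter is expected in this assay. For compound 4 the expected value is 35 nM, with a range from 15 nM to 85 nM. The expected step is a 1.1-fold lower number from compound 2 to compound 4 (0.02 log units; within the scatter), within the scatter.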

Compound 4, inhibition constant: 14 nM
The estimate for compound 4 lay 2.5-fold (0.40 log units) above the measured number; measured number below the stated range.
By their numbers in this assay, from the lowest: compound 4; then compounds 1 and 2 (each within the scatter of the next); then compound 3.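

In this assay, moving the chlorine alone is enough for a step beyond the scatter: 2-chlorophenyl in place of 3-chlorophenyl gives a 2.6-fold lower number from compound 2 to compound 4 (0.42 log units; beyond the scatter), with the heavy-atom count of the group unchanged. Chloro in place of methoxy on an aromatic carbon gives a 2.2-fold lower number from compound 1 to compound 4 (0.35 log units; beyond the scatter), so changes on this aryl group do not all stay within the scatter. Nothing available explains either step. As far as these compounds go, whether 2-fluorophenyl, 2-bromophenyl or 2-methylphenyl would match 2-chlorophenyl in this assay remains open.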